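This account rests on a few compounds, and the source may have more. Where it says the series, first, only, none or still open, it means among the compounds named here.

Compound 1 `COc1ccccc1-n1c(Nc2nc(-c3ccccc3)cs2)n[nH]c1=S` is the reference point of this set. In a functional assay on the whole organism (strain Swiss albino) for inhibition, with Mus musculus as the target, with a stated time of 4 h (on this read-out lower numbers stand for an effect already at smaller amounts and higher numbers for an effect only at larger amounts of compound), compound 1 gives 300 mg/kg, level with compound 2 `COc1ccccc1-n1c(Nc2nc(-c3ccc(Br)cc3)cs2)n[nH]c1=S`, which gives 300 mg/kg, the two together standing highest of the three numbers. Within the data shown here, compound 3 `COc1ccccc1-n1c(Nc2nc(-c3ccc(Cl)cc3)cs2)n[nH]c1=S` gives 100 mg/kg, and the change a 3.0-fold lower number from compound 1 to compound 3 (0.48 log units; beyond the scatter) is the only step beyond the scatter among the measured compounds. Compound 4 `Cc1ccc(-n2c(Nc3nc(-c4ccccc4)cs3)n[nH]c2=S)cc1` differs from compound 1 in a different part of the molecule: 4-methylphenyl in place of 2-methoxyphenyl on an aromatic nitrogen. Among the measured compounds shown here, none of the measured steps touches the group on the ring nitrogen, so no measured step bears directly on this change, and no shift beyond the scatter is expected. Compound 4 is therefore estimated at 300 mg/kg, within 100 mg/kg to 1000 mg/kg, an expected step of no change at the digits printed from compound 1 to compound 4 (within the scatter).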

Compound 4, minimum effective dose: 300 mg/kg
The estimate for compound 4 equals the measured number at the digits printed, within the range that was stated.
By their numbers in this assay, from the lowest: compound 3; then compounds 1, 2 and 4 (each within the scatter of the next).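

Among these compounds, the first measured change on the aromatic nitrogen, 4-methylphenyl in place of 2-methoxyphenyl, gives no change at the digits printed from compound 1 to compound 4 (within the scatter) in this assay. The entering group carries no oxygen and no hydrogen-bond acceptor, yet the read-out stays level, though this single exchange cannot separate the swap of substituent from its change of place on the phenyl ring. Nothing available explains this outcome.

On these data alone, whether an amine or a carboxylic acid on this phenyl ring, or a longer chain in its place on the nitrogen, would hold the same level remains open. As far as these compounds go, it also remains open whether the chloro step seen with the 2-methoxyphenyl group carries over to the 4-methylphenyl series.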